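The source may hold more compounds than are shown below. What is called first, only, known or untested is meant among the compounds shown, and "the series" means these compounds.

Compound 1, `C=C1C(=O)[C@]23C[C@@]1(O)CC[C@H]2c1ccc(O)c(C)c1[C@@H]3Cn1cc(-c2ccc(F)cc2)nn1`, is the weaker of the two compounds with a number in a functional assay on MCF7 cells (Homo sapiens) for cytotoxicity, read by MTT assay, with a stated time of 4 days; on this read-out lower numbers stand for stronger inhibition and higher numbers for weaker inhibition: compound 1 gives 1700 nM. Among the measured compounds shown here, compound 2, `C=C1C(=O)[C@]23C[C@@]1(O)CC[C@H]2c1ccc(OS(=O)(=O)c2ccc(C)cc2)c(C)c1[C@@H]3Cn1cc(-c2ccc(F)cc2)nn1`, gives 330 nM in this assay, and the step of a 5.2-fold lower number from compound 1 to compound 2 (0.71 log units; beyond the scatter) is the only single change measured here. Compound 3, `C=C1C[C@]23C[C@@]1(O)CC[C@@H]2c1cccc(C)c1[C@@H]3Cn1cc(-c2ccc(F)cc2)nn1`, reaches only the limit of this assay, > 20000 nM, so it sets no number.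

Compound 4, `C=C1C(=O)[C@]23C[C@@]1(O)CC[C@H]2c1ccc(O)c(C)c1[C@@H]3Cn1cc(-c2ccc(OC)cc2)nn1`, differs from compound 1 by methoxy in place of fluoro on an aromatic carbon. For the measured compounds named here, no measured step touches that outer phenyl ring; the one known step, a 5.2-fold lower number from compound 1 to compound 2 (0.71 log units; beyond the scatter), sits elsewhere on the shared core. A step not beyond the scatter is therefore expected, no change at the digits printed from compound 1 to compound 4 (within the scatter). Compound 4 is estimated at 1700 nM in this assay, between 600 nM and 5000 nM.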

Compound 4, half-maximal inhibitory concentration: 1710 nM
The estimate for compound 4 lay 1.0-fold (0.00 log units) below the measured number, and the stated range covers the measured number.
By their numbers in this assay, from the lowest: compound 2; then compounds 1 and 4 (each within the scatter of the next). At a limit, above all of these: compound 3.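

The outer phenyl ring now has its first measured change: a 1.0-fold higher number from compound 1 to compound 4 (0.00 log units; within the scatter) in this assay, for 4-fluorophenyl to 4-methoxyphenyl. On this aromatic carbon, para to a large group, the two groups cannot be told apart by this read-out, although methoxy has a hydrogen-bond acceptor and fluoro has none under the count used here. Nothing available explains why the numbers match. From the compounds shown here alone, whether an amine or a carboxylic acid at this position would also leave the number within the scatter remains open, as does whether the same swap would behave alike on compound 2.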